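Compound 3 against compound 2: chlorine placement and growth inhibition

This account rests on a few compounds, and the source may have more. Where it says the series, first, only, none or still open, it means among the compounds named here.

Measured so far:
- Compound 1 `O=C(/C=C\c1ccc([N+](=O)[O-])cc1)N1N=C(c2ccncc2)OC1c1c[nH]c2ccccc12` — in an ADME assay on A549 cells (Homo sapiens) for cytotoxicity, read by MTT assay, with a stated time of 48 h (on this read-out lower numbers stand for stronger inhibition of growth and higher numbers for weaker inhibition of growth), compound 1 gives only a limit, > 30 ug/mL.
- Compound 2 `O=C(/C=C\c1cccc(Cl)c1Cl)N1N=C(c2ccncc2)OC1c1c[nH]c2ccccc12` — in this assay compound 2 likewise gives only a limit, > 30 ug/mL.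

For the measured compounds named here, the single measured step, a step that the two limits leave unreadable from compound 1 to compound 2, cannot be read because both values sit at the limit of > 30 ug/mL in this assay, at which 2 of the 2 values shown sit. Compound 2 therefore stands at the assay limit with no number of its own, and every other value shown is a limit as well.

Compound 3 `O=C(/C=C/c1c(Cl)cccc1Cl)N1N=C(c2ccncc2)OC1c1c[nH]c2ccccc12` differs from compound 2 by 2-(2,6-dichlorophenyl)ethenyl in place of 2-(2,3-dichlorophenyl)ethenyl on a carbonyl carbon. Going by the values given here, no measured step bears directly on this rearrangement; the only step available, a step that the two limits leave unreadable from compound 1 to compound 2, is unreadable, so it neither supports nor rules out a change.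

Compound 3 is expected to remain at the limit, with an estimate of 40 ug/mL and a range from 15 ug/mL to 100 ug/mL. The expected step that the limit leaves unreadable from compound 2 to compound 3 is none beyond the scatter.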

Compound 3, concentration for 50% growth inhibition: > 30 ug/mL
Compound 3 was reported as a limit (the forecaster's own chance of this, stated with the estimate: 80%); the middle value is on the limit's open side.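

Compound 3 also gives only a limit, > 30 ug/mL. No step among compound 1, compound 2 and compound 3 can therefore be read: the limit of > 30 ug/mL in this assay, at which 3 of the 3 values shown sit.

The compounds shown leave open whether the 2-(4-nitrophenyl)ethenyl, 2-(2,3-dichlorophenyl)ethenyl and 2-(2,6-dichlorophenyl)ethenyl groups differ at all in growth inhibition.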